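A Tetrazole in Place of the Hydroxy Acid

The source may hold more compounds than are shown below. What is called first, only, known or untested is meant among the compounds shown, and "the series" means these compounds.

Of the compounds shown here, two have so far been measured in an assay on CHO cells for displacement of a labelled ligand from Glucagon receptor (Homo sapiens); on this read-out higher numbers stand for weaker inhibition and lower numbers for stronger inhibition. Compound 1 `O=C(O)CCNC(=O)c1ccc(Cc2cc(-c3ccc(OC(F)(F)F)cc3)n(C3CCCCC3)n2)cc1` gives 1700 nM in this assay. Compound 2 `O=C(NC[C@@H](O)C(=O)O)c1ccc(Cn2nc(-c3cc(Cl)cc(Cl)c3)cc2-c2ccc(OC(F)(F)F)cc2)cc1` gives 28 nM in this assay, the lower of the two numbers, and its gap to compound 1 lies beyond the scatter. Going by the values given here, no single-point step between measured compounds is available, so the two values are simply set side by side.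

Compound 3 `O=C(NCc1nn[nH]n1)c1ccc(Cn2nc(-c3cc(Cl)cc(Cl)c3)cc2-c2ccc(OC(F)(F)F)cc2)cc1` has not yet been measured. It differs from compound 2 in one place: 2H-tetrazol-5-yl in place of carboxy(hydroxy)methyl on a saturated chain carbon bound to an amide-type nitrogen. The remainder of compound 2, including the shared core and its substituted aryl rings, is kept unchanged.

Nothing measured here shows what this exchange does in this assay. The step from compound 2 to compound 3 is expected to be a 2.1-fold higher number from compound 2 to compound 3 (0.33 log units; beyond the scatter), a modest move towards a weaker number or none beyond the scatter, given that compound 2 stands at 28 nM. For compound 3 the estimate is therefore 60 nM, with a range from 15 nM to 250 nM.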

Compound 3, half-maximal inhibitory concentration: 120 nM
Estimate against measurement, compound 3: 2.0-fold (0.30 log units) below; the range from low to high includes it.
By their numbers in this assay, from the lowest: compound 2; then compound 3; then compound 1.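

In this assay, going by these compounds alone, putting 2H-tetrazol-5-yl in place of carboxy(hydroxy)methyl on a saturated chain carbon bound to an amide-type nitrogen gives a 4.3-fold higher number from compound 2 to compound 3 (0.63 log units; beyond the scatter) and provides the first single-place comparison in this small set. The earlier compounds shown here could show no such thing, whereas this pair shows that the position accepts a five-membered aromatic ring with 4 hetero atoms in place of a carboxy(hydroxy)methyl group bearing a defined stereocentre, at a modest cost, with compound 2 keeping the lower number of the pair. Nothing available shows which part of the exchange accounts for this step.

The exchange alters the ring, the carboxy group, the hydroxy group and the stereocentre in one move, so the pair cannot assign the step to any one of them, and a plain 2-carboxyethyl group without the hydroxy group would be needed to begin separating them. As far as these compounds go, it also remains open how a longer chain carrying the tetrazole, such as 2-(2H-tetrazol-5-yl)ethyl in place of (2H-tetrazol-5-yl)methyl, would stand in this assay.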